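The source may hold more compounds than are shown below. What is called first, only, known or untested is meant among the compounds shown, and "the series" means these compounds.

Working notes on the series. Three compounds have a number in a functional assay on SK-MEL-5 cells (Homo sapiens) for cytotoxicity, read by sulforhodamine B assay, with a stated time of 48 h (a higher number here means a weaker inhibitor of growth, a lower number a stronger inhibitor of growth), so far. Compound 1 `Nc1nc(Cl)c2ncn(Cc3ccccc3CCl)c2n1` gives 8510 nM in this assay, the highest of the three numbers. Compound 3 `ClCc1ccc(Cn2cnc3c(Cl)nc(Cl)nc32)cc1` gives 6460 nM in this assay, which lies within the scatter of the number for compound 1, so no order can be read between these two. Compound 2 `ClCc1cccc(Cn2cnc3nc(Cl)nc(Cl)c32)c1` gives 1200 nM in this assay, a lower number than that of compound 1 by a margin that lies beyond the scatter. No pair among these three differs in a single place, so none of the gaps between them can be tied to one structural change.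

Compound 4 `ClCc1ccccc1Cn1cnc2c(Cl)ncnc21` has not yet been measured in this assay. It differs from compound 1 as follows: hydrogen in place of amino on an aromatic carbon. For the measured compounds named here, no measured pair shows what this change does, so there is no step to lean on. With nothing in the data pointing either way, the step from compound 1 is expected to be small, within the scatter, in no fixed direction: a 1.1-fold lower number from compound 1 to compound 4 (0.03 log units; within the scatter). For compound 4 the number expected in this assay is 8000 nM, with a range from 2500 nM to 25000 nM.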

Compound 4, concentration for 50% growth inhibition: 1410 nM
The estimate for compound 4 lay 5.7-fold (0.75 log units) above the measured number; measured number below the stated range.
By their numbers in this assay, from the lowest: compounds 2 and 4 (each within the scatter of the next); then compounds 3 and 1 (each within the scatter of the next).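

In this assay, for the compounds shown here, hydrogen in place of amino on the aromatic carbon between two ring nitrogen atoms gives a 6.0-fold lower number from compound 1 to compound 4 (0.78 log units; beyond the scatter), and this is the first gap that can be tied to a single structural change. The amino group at this position is therefore not required for growth inhibition in this pair, and the compound without it is the stronger inhibitor of growth, although one pair on one core sets no general rule. Nothing on hand explains this step, so the result stands as an observation only.

The compounds shown carry only amino or hydrogen on this carbon in this comparison, so the effect of a methylamino, methoxy or methyl group there remains open. Going by these compounds alone, it is also open whether the same change gives a step of similar size and direction with the chloromethyl group placed as in compound 2 or compound 3, as no pair with either arrangement isolates this change.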